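Methoxy addition on a biaryl series and cell viability

A few compounds are considered here, and "the series" means these few. Any claim that something is new, unique, unknown or untested is made for them only; others in the source may bear on it.

Compound 1 `COc1ccccc1-c1ccccc1O` gives 54 ug/mL in an ADME assay on HEK293 cells (Homo sapiens) for cytotoxicity, read by MTT assay, with a stated time of 3 days; a lower number here means a stronger inhibitor, a higher number a weaker inhibitor. Compound 2 `COc1ccc(-c2ccccc2)cc1` gives 17 ug/mL in this assay, the lowest of the two numbers here, and its nearest neighbour is compound 1, a gap beyond the scatter. The difference between the core of compound 1 and the core of compound 2 is not broken down here. Compound 3 `COc1ccc(-c2ccccc2O)c(OC)c1` returns only a limit in this assay, > 100 ug/mL, so it is not a number. Compound 3 therefore stands at the limit of > 100 ug/mL in this assay, at which 1 of the 3 values shown sits. The change from compound 1 to compound 3 is methoxy in place of hydrogen on an aromatic carbon, and it gave an at least 1.8-fold higher number from compound 1 to compound 3 (0.26 log units; that floor lies within the scatter), a floor that lies within the scatter.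

Compound 4 `COc1ccc(-c2ccccc2)cc1OC` is not yet measured in this assay. It differs from compound 2 by methoxy in place of hydrogen on an aromatic carbon. This is the same kind of change as that from compound 1 to compound 3, but not the same: in compound 3 the new methoxy sits meta to a methoxy group and para to a group of 7 heavy atoms, while in compound 4 it sits ortho to a methoxy group and meta to a group of 6 heavy atoms.

The expectation rests on compound 2 with 17 ug/mL and on the step of an at least 1.8-fold higher number from compound 1 to compound 3 (0.26 log units; that floor lies within the scatter), which is taken as a guide for direction only. The step from compound 2 to compound 4 is expected to be a 2.1-fold higher number from compound 2 to compound 4 (0.31 log units; beyond the scatter). Compound 4 is estimated at 35 ug/mL, with a range from 15 ug/mL to 90 ug/mL.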

Compound 4, half-maximal inhibitory concentration: 26 ug/mL
Compound 4: middle estimate off by 1.3-fold (0.13 log units), on the high side, within the range that was stated.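

Methoxy in place of hydrogen on an aromatic carbon, read on the core of compound 2, gives a 1.5-fold higher number from compound 2 to compound 4 (0.18 log units; within the scatter), a step too small to count as a real shift in this assay. Set beside the earlier step on the core of compound 1, it gives no firm reading on whether the change carries from one core to the other: the same change on two cores in this assay, an at least 1.8-fold higher number (0.26 log units; that floor lies within the scatter) from compound 1 to compound 3 and a 1.5-fold higher number (0.18 log units; within the scatter) from compound 2 to compound 4; the limit leaves it open whether they differ. Compound 3 gives > 100 ug/mL, which is a limit and not a number, and the two steps therefore show neither a shared size for the change nor a shared direction beyond the scatter, while the new methoxy also does not sit in the same place on the two cores.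

The compounds shown leave open whether another group on the same aromatic carbon, such as an amine, a carboxylic acid or a longer alkoxy chain, would move the number beyond the scatter where methoxy on the core of compound 2 does not. Going by these compounds alone, they also leave open how much of any difference between the two cores belongs to the core itself, since no single-place step joins the core of compound 1 to the core of compound 2.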